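Swapping ethyl for bromo: what two measurements suggest

The source may report more compounds than this note shows. Statements on the series, on what has been measured and on what is new or still open speak of the compounds shown alone.

Compound 1 `Cc1cccc(NS(=O)(=O)c2ccc(N3CCNC3=O)cc2)c1` gives 370 nM
Compound 2 `CCc1cccc(NS(=O)(=O)c2ccc(N3CCNC3=O)cc2)c1` gives 450 nM

Among the measured compounds shown here, in a functional assay (CEM-VLB cells, Homo sapiens) for antiproliferative activity, read by sulforhodamine B assay, with a stated time of 48 h (on this read-out higher numbers stand for weaker inhibition and lower numbers for stronger inhibition), compound 2 stands at 450 nM and cannot be told apart from compound 1, its only measured neighbour. The next compound, compound 3 `O=C1NCCN1c1ccc(S(=O)(=O)Nc2cccc(Br)c2)cc1`, has bromo in place of ethyl on an aromatic carbon. For the measured compounds named here, the one measured step, a 1.2-fold higher number from compound 1 to compound 2 (0.09 log units; within the scatter), concerns a different change and stayed small, and no bromo compound has a value yet. So no step beyond the scatter is expected in this assay, and the estimated change is a 1.1-fold lower number from compound 2 to compound 3 (0.05 log units; within the scatter) at most a guide. Compound 3 is estimated at 400 nM, with an expected range from 150 nM to 1000 nM.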

Compound 3, half-maximal inhibitory concentration: 250 nM
Estimate against measurement, compound 3: 1.6-fold (0.20 log units) above; the range from low to high includes it.
By their numbers in this assay, from the lowest: compounds 3, 1 and 2 (each within the scatter of the next).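

In this assay, bromo in place of ethyl on this aromatic carbon gives a 1.8-fold lower number from compound 2 to compound 3 (0.26 log units; within the scatter) and bromo in place of methyl gives a 1.5-fold lower number from compound 1 to compound 3 (0.17 log units; within the scatter) on the same ring, so a group other than a saturated chain also stays within the scatter here. No measurement shown gives a reason for this closeness. Still open, from the compounds shown here alone, is whether an amine, a carboxylic acid or a longer chain at this position would move the number beyond the scatter, and whether bromo would behave alike elsewhere on the ring.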